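The compounds below may be only part of what the source reports. "The series", "measured", "known", "first", "only" and "open" are said of these compounds alone.

For the measured compounds named here, in a functional assay on ASK cells (Rattus norvegicus) for cytotoxicity, read by sulforhodamine B assay (on this read-out lower numbers stand for an effect already at smaller amounts and higher numbers for an effect only at larger amounts of compound), compound 1 `C=C1CC[C@@H]2[C@](C)(CO)[C@H](OC(C)=O)CC[C@@]2(C)[C@@H]1C/C=C1/C(=O)OC[C@H]1O` gives 58.1 uM and stands as the higher of the two numbers so far. Compound 2 `C=C1CC[C@@H]2[C@](C)(CO[Si](C(C)C)(C(C)C)C(C)C)[C@H](O)CC[C@@]2(C)[C@@H]1C/C=C1/C(=O)OC[C@H]1O` gives 2.85 uM, a lower number, with the gap between them beyond the scatter. Compound 3 `C=C1CC[C@@H]2[C@](C)(CO[Si](C)(C)C(C)(C)C)[C@H](OC(C)=O)CC[C@@]2(C)[C@@H]1C/C=C1/C(=O)OC[C@H]1O` departs from compound 1 in one place: a group of 7 heavy atoms (6 carbon, 1 silicon; no ring) in place of a hydrogen atom, on an oxygen on a saturated carbon. Going by the values given here, no measured pair isolates this change, so the forecast rests on limited evidence. It leans on compound 2, which also has a silicon-bearing group on that oxygen and gives 2.85 uM, although compound 2 differs from compound 1 elsewhere too. A sizeable move toward lower numbers, beyond the scatter, is therefore expected in this assay. The expected step is a 9.7-fold lower number from compound 1 to compound 3 (0.99 log units; beyond the scatter). Compound 3 is estimated at 6 uM, with an expected range from 2 uM to 18 uM.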

Compound 3, concentration for half-maximal effect: 8.17 uM
Compound 3: middle estimate off by 1.4-fold (0.13 log units), on the low side; the measured number falls inside the stated range.
By their numbers in this assay, from the lowest: compound 2; then compound 3; then compound 1.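

In this assay, this change alone, a group of 7 heavy atoms (6 carbon, 1 silicon; no ring) in place of a hydrogen atom, on an oxygen on a saturated carbon, gives a 7.1-fold lower number from compound 1 to compound 3 (0.85 log units; beyond the scatter). With the rest of the structure held the same, this shows that a silicon-bearing group on this oxygen is enough on its own to move the number beyond the scatter, which compound 2, differing from compound 1 in a second place too, could not show. No measurement available here accounts for the step.

As far as these compounds go, it remains open whether silicon itself matters, or whether a benzyl or a methyl on the same oxygen would give a similar step. From the compounds shown here alone, it is also open whether this change would give a step of similar size without the acetyl group found elsewhere on the core of compound 1.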